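Repeating an Amino Addition on a Rearranged Core

The compounds below may be only part of what the source reports. "The series", "measured", "known", "first", "only" and "open" are said of these compounds alone.

Measured compounds:
Compound 1: `ClCc1ccc(Cn2cnc3c(Cl)ncnc32)cc1`, 1090 nM
Compound 2: `Nc1nc(Cl)c2ncn(Cc3ccc(CCl)cc3)c2n1`, 16600 nM
Compound 3: `ClCc1ccccc1Cn1cnc2c(Cl)ncnc21`, 22900 nM

All three were tested in a functional assay on TK-10 cells (Homo sapiens) for cytotoxicity, read by sulforhodamine B assay, with a stated time of 48 h; on this read-out higher numbers stand for weaker inhibition of growth and lower numbers for stronger inhibition of growth. Compound 1 and compound 2 differ in one place: amino in place of hydrogen on an aromatic carbon. That single change produced a 15-fold higher number from compound 1 to compound 2 (1.18 log units; beyond the scatter), so the added amino group went with a clear loss of growth inhibition on this core.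

Compound 3 is built from the same atoms as compound 1, joined differently; the difference between the two cores is not broken down here. Compound 3 and compound 2 give numbers that lie within the scatter of each other, while compound 1 gives a number far lower than either, beyond the scatter.

Compound 4, `Nc1nc(Cl)c2ncn(Cc3ccccc3CCl)c2n1`, has not yet been measured. It differs from compound 3 by amino in place of hydrogen on an aromatic carbon. The place of the change is described in the same words as for the earlier pair, so this is the same change carried out on the core of compound 3 rather than that of compound 1. Because compound 1 to compound 2 gave a 15-fold higher number from compound 1 to compound 2 (1.18 log units; beyond the scatter), compound 4 is expected to show a step of similar size, an 11-fold higher number from compound 3 to compound 4 (1.04 log units; beyond the scatter). Compound 4 is therefore estimated at 250000 nM, with a range from 70000 nM to 800000 nM. Since compound 3 already gives a high number, the assay may report only a limit for compound 4 rather than a number.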

Compound 4, concentration for 50% growth inhibition: 17800 nM
Estimate against measurement, compound 4: 14-fold (1.15 log units) above, outside the stated range (below it).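

In this assay, amino in place of hydrogen on an aromatic carbon gave a 1.3-fold lower number from compound 3 to compound 4 (0.11 log units; within the scatter), so on the core of compound 3 the added group made no difference that can be told apart from the scatter of repeated measurements. Set beside the earlier pair, the same change did not carry over from one core to the other: the same change on two cores in this assay, a 15-fold higher number (1.18 log units; beyond the scatter) from compound 1 to compound 2 and a 1.3-fold lower number (0.11 log units; within the scatter) from compound 3 to compound 4, 20-fold (1.29 log units) apart, beyond the scatter of two such steps. This shows that the large step seen on the core of compound 1 cannot be taken as a fixed value for this change across the series, but two pairs do not show why the two cores answer differently, nor how a further core would answer.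

The compounds shown carry only hydrogen or amino at this place, between two ring nitrogen atoms, so it remains open whether a methylamino or a hydroxyl group there would follow the result for amino on either core. Going by these compounds, it also remains open how each core would respond to the amino change if a methoxy group stood in place of the chloro group on the same ring.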